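Pyrrolidin-2-yl in place of piperidin-4-yl: compound 3

This account rests on a few compounds, and the source may have more. Where it says the series, first, only, none or still open, it means among the compounds named here.

In an ADME assay on MT2 cells (Homo sapiens) for cytotoxicity, read by XTT assay, with a stated time of 4 days (on this read-out lower numbers stand for higher toxicity in this test and higher numbers for lower toxicity in this test), compound 1 `Cc1nc(C(NC(=O)C(=O)Nc2ccc(Cl)cc2)C2CCNCC2)sc1CO` stands at > 81000 nM as a limit and not a number. Compound 2 `Cc1ccc(NC(=O)C(=O)NC(c2nc(C)c(CCO)s2)C2CCCCN2)cc1F` gives 85000 nM in this assay as a measured number. Compound 3 `Cc1nc(C(NC(=O)C(=O)Nc2ccc(Cl)cc2)C2CCCN2)sc1CO` carries pyrrolidin-2-yl in place of piperidin-4-yl on a saturated chain carbon bound to an amide-type nitrogen and an aromatic carbon and has not yet been measured. Among the measured compounds shown here, no measured pair shows this change, so in this assay the expected step that the limit leaves unreadable from compound 1 to compound 3 is none beyond the scatter. Compound 3 is estimated at 85000 nM with an expected range from 35000 nM to 170000 nM in this test.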

Compound 3, half-maximal cytotoxic concentration: 45000 nM
For compound 3 the middle estimate is 1.9-fold (0.28 log units) above the measured one; the measured number falls inside the stated range.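

In this assay, pyrrolidin-2-yl in place of piperidin-4-yl on a saturated chain carbon bound to an amide-type nitrogen and an aromatic carbon brings an at least 1.8-fold lower number from compound 1 to compound 3 (0.25 log units; that floor lies within the scatter). Among the compounds shown here, this is the first step read at this position, and compound 3 gives a number where compound 1 gives only a limit. The full size of the step cannot be told because one end of it is not a number: the limit of > 81000 nM in this assay, at which 1 of the 3 values shown sits.

The compounds shown leave open how a morpholin-2-yl group or an open-chain amine on that carbon would read in this assay.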